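A few compounds are considered here, and "the series" means these few. Any claim that something is new, unique, unknown or untested is made for them only; others in the source may bear on it.

Series around a shared core: compound 1 `COC(=O)c1ccc(NC(=O)N[C@H]2CC[C@H](Oc3ccc(F)cc3)CC2)cc1`, compound 2 `O=C(Nc1cccc([N+](=O)[O-])c1)N[C@H]1CC[C@H](Oc2ccc(F)cc2)CC1` and compound 3 `O=C(Nc1ccccc1Br)N[C@H]1CC[C@H](Oc2ccc(F)cc2)CC1` carry differently substituted phenyl groups on an amide-type nitrogen. In a functional assay on CRL2813 cells (Homo sapiens) for cytotoxicity, read by sulforhodamine B assay, with a stated time of 5 days (on this read-out higher numbers stand for weaker inhibition and lower numbers for stronger inhibition), compound 1 gives 11600 nM, compound 2 gives 6700 nM and compound 3 gives 7700 nM. Compound 3 stands with compound 2 nearest and compound 1 furthest, yet both of those gaps lie within the scatter, so no order among the three can be read from this assay. Going by the values given here, the one single-point step measured so far, a 1.1-fold higher number from compound 2 to compound 3 (0.06 log units; within the scatter), swaps one ring substituent for another and leaves the read-out essentially unmoved.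

Compound 4 `O=C(Nc1ccccc1)N[C@H]1CC[C@H](Oc2ccc(F)cc2)CC1` follows from compound 3 by hydrogen in place of bromo on an aromatic carbon. Among the compounds with values here, no measured step removes a ring substituent outright; the step from compound 2 to compound 3 is the closest precedent, a change of one ring substituent into another, and it stayed within the scatter, while compound 1 with its own ring substituent also sits within the scatter of compound 3. Altering the aryl substituent has so far produced no step beyond the scatter in this assay, and none is expected here. Compound 4 is estimated at 8500 nM, range 3000 nM to 25000 nM, which corresponds to an expected step of a 1.1-fold higher number from compound 3 to compound 4 (0.04 log units; within the scatter).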

Compound 4, half-maximal inhibitory concentration: 20000 nM
Beside the measured number, compound 4's estimate is 2.4-fold (0.37 log units) below it; low and high end bracket the measured number.
By their numbers in this assay, from the lowest: compounds 2, 3, 1 and 4 (each within the scatter of the next, the first and the last beyond it).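

In this assay, going by these compounds alone, the bare phenyl gives the first steps beyond the scatter at this aromatic carbon: hydrogen in place of bromo gives a 2.6-fold higher number from compound 3 to compound 4 (0.41 log units; beyond the scatter), and hydrogen in place of nitro gives a 3.0-fold higher number from compound 2 to compound 4 (0.47 log units; beyond the scatter), both modest, whereas exchanging one ring substituent for another in a 1.1-fold higher number from compound 2 to compound 3 (0.06 log units; within the scatter) moved nothing measurable. So replacing a substituent with hydrogen can shift this read-out towards weaker inhibition where a swap between these two substituents did not, but compound 1 goes against any general rule, since hydrogen in place of methoxycarbonyl gives only a 1.7-fold higher number from compound 1 to compound 4 (0.24 log units; within the scatter). Nothing at hand gives a reason for these steps or for the exception.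

Going by these compounds, it remains open whether a fluoro, a methyl or an amine on the ring would keep the read-out close to compound 3 at 7700 nM or let it fall back towards compound 4 at 20000 nM. Also open, on these data alone, is whether the step from bromo to hydrogen keeps its size when the fluorine on the shared core gives way to a chlorine.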